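Swapping a pyridyl arm for 2-methylphenyl on the core

The source may hold more compounds than are shown below. What is called first, only, known or untested is meant among the compounds shown, and "the series" means these compounds.

Measured in a functional assay on HCT-15 cells (Homo sapiens) for cytotoxicity, in the presence of a further agent that is not named here; a lower number here means a stronger inhibitor, a higher number a weaker inhibitor:
compound 1, `Clc1cccc(-c2cc(-c3ccc(Cl)o3)cc(-c3cccs3)n2)c1`: 15500 nM
compound 3, `Cc1ccc(-c2cc(-c3ccoc3)cc(-c3ccsc3)n2)cc1`: 44800 nM
compound 2, `Clc1ccc(-c2cc(-c3cccnc3)nc(-c3ccsc3)c2)o1`: > 50000 nM, a limit of the assay and not a number

Compound 2 stands at the limit of > 50000 nM in this assay, at which 1 of the 3 values shown sits, while compound 1 and compound 3 each give a number. Compound 4, `Cc1ccccc1-c1cc(-c2ccc(Cl)o2)cc(-c2ccsc2)n1`, has not been measured. It differs from compound 2 in one place: 2-methylphenyl in place of pyridin-3-yl on an aromatic carbon. For the measured compounds named here, no measured pair isolates this change, so its size can only be expected. Compound 1 and compound 3, which carry a substituted phenyl group rather than a pyridyl, both give numbers, so a modest gain is expected; the step from compound 2 to compound 4 is estimated at an at least 2.0-fold lower number from compound 2 to compound 4 (0.30 log units; that floor lies within the scatter). Compound 4 is expected to give 25000 nM, within a range from 8000 nM to 80000 nM.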

Compound 4, half-maximal inhibitory concentration: 4630 nM
The estimate for compound 4 lay 5.4-fold (0.73 log units) above the measured number; the measured number lies below the stated range.
By their numbers in this assay, from the lowest: compound 4; then compound 1; then compound 3. At a limit, above all of these: compound 2.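

In this assay, 2-methylphenyl in place of pyridin-3-yl on the aromatic carbon next to the ring nitrogen gives an at least 10-fold lower number from compound 2 to compound 4 (1.03 log units; beyond the scatter). For the compounds shown here, this is the first single change that can be read here, and it shows that the group on this carbon alone can carry a compound from a limit of the assay to a measured number. The step is only a floor, for compound 2 stands at a limit and not a number: the limit of > 50000 nM in this assay, at which 1 of the 4 values shown sits.

The compounds shown leave open whether the methyl group or the carbon-only ring carries the step. On these data alone, how an unsubstituted phenyl, or an amine on that ring, would read in this assay also remains open.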